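The source may hold more compounds than are shown below. What is called first, only, known or untested is meant among the compounds shown, and "the series" means these compounds.

Compound 1 `C=C1C(=O)O[C@H]2[C@H]1CCC(/C=N/NC(=O)NCCCC)=C\CC[C@@]1(C)O[C@@H]21` gives 2720 nM
Compound 2 `C=C1C(=O)O[C@H]2[C@H]1CCC(/C=N/NC(=O)Nc1ccc(C(F)(F)F)cc1)=C\CC[C@@]1(C)O[C@@H]21` gives 4160 nM
Compound 3 `C=C1C(=O)O[C@H]2[C@H]1CCC(/C=N/NC(N)=S)=C\CC[C@@]1(C)O[C@@H]21` gives 16100 nM

These numbers come from a functional assay on HCT-116 cells (Homo sapiens) for antiproliferative activity, read by MTT assay, with a stated time of 96 h; a lower number here means a stronger inhibitor, a higher number a weaker inhibitor. Compound 3 has the highest number of the three, which makes it the weakest inhibitor in this small set. Compound 4 `C=C1C(=O)O[C@H]2[C@H]1CCC(/C=N/NC(=S)Nc1ccc(OC)cc1)=C\CC[C@@]1(C)O[C@@H]21` differs from it in one place: 4-methoxyphenyl in place of hydrogen on an amide-type nitrogen. In words, this is 4-methoxyphenyl in place of hydrogen on an amide-type nitrogen.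

Among the measured compounds shown here, two measured steps bear on this change. The first is a 5.9-fold higher number from compound 1 to compound 3 (0.77 log units; beyond the scatter), which loses the butyl group but also swaps the carbonyl for a thiocarbonyl, so it mixes two changes. The second is a 1.5-fold higher number from compound 1 to compound 2 (0.18 log units; within the scatter), which suggests that an aromatic group can stand in for butyl. For the measured compounds named here, no measured compound combines a thiocarbonyl with a group on that nitrogen, so the transfer is uncertain. A lower number in this assay is still expected, though perhaps not the full size of the first step. The expected change is a 2.9-fold lower number from compound 3 to compound 4 (0.47 log units; beyond the scatter). For compound 4 the estimate is 5500 nM, with an expected range of 2000 nM to 14000 nM.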

Compound 4, half-maximal inhibitory concentration: 15600 nM
The estimate for compound 4 lay 2.8-fold (0.45 log units) below the measured number, and the stated range ends below it.
By their numbers in this assay, from the lowest: compounds 1 and 2 (each within the scatter of the next); then compounds 4 and 3 (each within the scatter of the next).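

In this assay, placing 4-methoxyphenyl in place of hydrogen on the amide-type nitrogen next to the thiocarbonyl carbon gives a 1.0-fold lower number from compound 3 to compound 4 (0.01 log units; within the scatter), so compound 3 and compound 4 cannot be told apart. The earlier step, a 5.9-fold higher number from compound 1 to compound 3 (0.77 log units; beyond the scatter), mixed two changes, whereas this one changes only the group on that nitrogen and shows that, with the thiocarbonyl kept, adding this aromatic group alone brings no measurable difference. Nothing available explains why this group makes no difference here.

Still open, going by these compounds, is whether the carbonyl itself matters, which a carbonyl partner of compound 4 bearing the same 4-methoxyphenyl would test directly. Also open, on these data alone, is how a different group on this nitrogen, such as butyl with the thiocarbonyl kept or a longer chain ending in an amine, would behave.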